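The source may report more compounds than this note shows. Statements on the series, on what has been measured and on what is new or still open speak of the compounds shown alone.

Going by the values given here, compound 2 `Cc1ccc(NC2=CC(=O)c3nc4n(c3C2=O)[C@H]2OC[C@@H](O)[C@H]2OC4)cc1` gives, in a functional assay on HeLa cells (Homo sapiens) for inhibition, read by sulforhodamine B assay (on this read-out higher numbers stand for weaker inhibition and lower numbers for stronger inhibition), 3860 nM, one of only two numbers in the set; the other belongs to compound 1 `O=C1C=C(Nc2ccc(I)cc2)C(=O)c2c1nc1n2[C@H]2OC[C@@H](O)[C@H]2OC1`, which gives 4070 nM, and the step of a 1.1-fold lower number from compound 1 to compound 2 (0.02 log units; within the scatter) stays within the scatter. Compound 3 `COc1cccc(NC2=CC(=O)c3c(nc4n3[C@H]3OC[C@@H](O)[C@H]3OC4)C2=O)c1` gives only a limit in this assay, > 8000 nM. One of the three values sits at the limit of > 8000 nM in this assay, at which 1 of the 3 values shown sits. Compound 4 `Cc1ccc(NC2=CC(=O)c3nc4n(c3C2=O)[C@H]2OC[C@@H](O)[C@H]2OC4)cc1C` differs from compound 2 by methyl in place of hydrogen on an aromatic carbon. Among the compounds with values here, no measured step adds a methyl in place of hydrogen; the single measured step, methyl in place of iodo on an aromatic carbon, moved the number little. The expectation for compound 4 is therefore no step beyond the scatter, a 1.1-fold lower number from compound 2 to compound 4 (0.03 log units; within the scatter). Compound 4 is estimated at 3600 nM, within 1500 nM to 8000 nM.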

Compound 4, half-maximal inhibitory concentration: 2690 nM
Compound 4: the middle estimate sits 1.3-fold (0.13 log units) above what was measured, within the range that was stated.
By their numbers in this assay, from the lowest: compounds 4, 2 and 1 (each within the scatter of the next). At a limit, above all of these: compound 3.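

In this assay, methyl on the aromatic carbon ortho to a methyl group, the 4-methylphenyl to 3,4-dimethylphenyl change, gives a 1.4-fold lower number from compound 2 to compound 4 (0.16 log units; within the scatter), so this position takes a second methyl without a step beyond the scatter. Replacing 4-iodophenyl with 3,4-dimethylphenyl likewise gives a 1.5-fold lower number from compound 1 to compound 4 (0.18 log units; within the scatter). Nothing at hand bears on a cause for either step. Open, as far as these compounds go, is whether an amine, a carboxylic acid or a longer chain such as ethyl at this position would move the number beyond the scatter.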